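The source may hold more compounds than are shown below. What is called first, only, known or untested is meant among the compounds shown, and "the series" means these compounds.

In a functional assay on A2780 cells (Homo sapiens) for antiproliferative activity, read by fluorescence, with a stated time of 72 h (a higher number here means a weaker inhibitor, a lower number a stronger inhibitor), compound 1 `CC(=O)N1CCN(C(=O)N2Cc3c(NC(=O)c4ccc(F)cc4)n[nH]c3C2(C)C)CC1` is reported only as a limit, > 10000 nM. Two compounds in the set give actual numbers. Compound 2 `CN1CCC(C(=O)N2Cc3c(NC(=O)C4CC4)n[nH]c3C2(C)C)CC1` stands at 1420 nM, the higher of the two, and compound 3 `CC(C)(C)C(=O)N1Cc2c(NC(=O)c3cccnc3)n[nH]c2C1(C)C` gives a lower number, 690 nM, a gap beyond the scatter. Compound 4 `CN1CCC(C(=O)N2Cc3c(NC(=O)NCc4ccccc4)n[nH]c3C2(C)C)CC1` differs from compound 2 in one place, with benzylamino in place of cyclopropyl on a carbonyl carbon. For the measured compounds named here, no measured pair in this assay covers this kind of change, so only a modest move towards a stronger inhibitor is expected, one that may not clear the scatter. The expected step is a 1.8-fold lower number from compound 2 to compound 4 (0.25 log units; within the scatter). For compound 4 the estimate is 800 nM, with an expected range of 150 nM to 4000 nM.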

Compound 4, half-maximal inhibitory concentration: 2680 nM
The estimate for compound 4 lay 3.4-fold (0.53 log units) below the measured number, and the stated range covers the measured number.
By their numbers in this assay, from the lowest: compound 3; then compounds 2 and 4 (each within the scatter of the next). At a limit, above all of these: compound 1.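

Within this assay, benzylamino in place of cyclopropyl on a carbonyl carbon gives a 1.9-fold higher number from compound 2 to compound 4 (0.28 log units; within the scatter). For the compounds shown here, this position therefore takes a six-membered aromatic ring and a hydrogen-bond donor with no shift that clears the scatter, a point the earlier compounds, which offered no single-place pair, could not show. Nothing among the data given bears on why this change has so little effect. Still open, as far as these compounds go, is how a smaller amine such as methylamino, or a morpholine, would behave on this carbonyl carbon.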